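The compounds below may be only part of what the source reports. "The series", "measured", "known", "first", "only" and "open" are said of these compounds alone.

Measured compounds in a functional assay on HCT-116 cells (Homo sapiens) for inhibition; a lower number here means a stronger inhibitor, a higher number a weaker inhibitor:
Compound 1 `CCNCc1cc(-c2c(C(=O)NCC)noc2-c2cc(C(C)C)c(O)cc2O)on1` gives 45 nM.
Compound 3 `CCCn1ccc(-c2c(C(=O)NCC)noc2-c2cc(C(C)C)c(O)cc2O)n1` gives 49 nM.
Compound 2 `CCNC(=O)c1noc(-c2cc(C(C)C)c(O)cc2O)c1-c1cc(C(=O)OCC)no1` gives "not determined" (no result reported), so no number is reported for it.

Among the two numbers shown, compound 1 stands with compound 3 inside the scatter: a 1.1-fold higher number from compound 1 to compound 3 (0.04 log units; within the scatter). Compound 4 `CCNC(=O)c1noc(-c2cc(C(C)C)c(O)cc2O)c1-c1cn[nH]c1` differs from compound 1 only at one ring position: 1H-pyrazol-4-yl in place of 3-((ethylamino)methyl)-1,2-oxazol-5-yl on an aromatic carbon. Among the measured compounds shown here, the single measured step that bears on this kind of exchange, a swap of the five-membered heteroaryl group at the same aromatic carbon, is a 1.1-fold higher number from compound 1 to compound 3 (0.04 log units; within the scatter), which is within the scatter. On that basis compound 4 is expected to stay near compound 1, with no step beyond the scatter: a 1.3-fold higher number from compound 1 to compound 4 (0.12 log units; within the scatter). The estimated value for compound 4 is 60 nM, in a range from 25 nM to 150 nM.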

Compound 4, half-maximal inhibitory concentration: 43 nM
Compound 4: the middle estimate sits 1.4-fold (0.14 log units) above what was measured, and the stated range covers the measured number.
By their numbers in this assay, from the lowest: compounds 4, 1 and 3 (each within the scatter of the next).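

In this assay, the change at this aromatic carbon to the smaller, unsubstituted 1H-pyrazol-4-yl leaves the number within the scatter: a 1.0-fold lower number from compound 1 to compound 4 (0.02 log units; within the scatter). The comparison with the propyl-bearing pyrazole gives the same reading: a 1.1-fold lower number from compound 3 to compound 4 (0.06 log units; within the scatter). Across these three compounds, neither the ethylaminomethyl side chain nor the propyl chain is needed to keep the number in this range, and nothing available explains this result.

Going by these compounds, it remains open whether a five-membered heteroaryl ring is needed here, or whether a phenyl ring would fit as well. Also open, on these data alone, is how a carboxylic acid or a longer amine chain on the ring would read.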